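The source may report more compounds than this note shows. Statements on the series, on what has been measured and on what is new or still open speak of the compounds shown alone.

In a functional assay on the whole organism (strain Wistar) for inhibition, with Rattus norvegicus as the target, read by paw edema, with a stated time of 30 min, at a dose of 10 mg/kg by the intraperitoneal route (on this read-out lower numbers stand for less inhibition and higher numbers for more inhibition at the one dose given (going by the name of the read-out)), compound 1 `O=C(N/N=C/c1cccc(Cl)c1)c1cccnc1Nc1cccc(C(F)(F)F)c1` gives 77.8% and compound 2 `O=C(N/N=C/c1ccc(O)cc1)c1cccnc1Nc1cccc(C(F)(F)F)c1` gives 59.3%. Going by the values given here, compound 2 therefore stands lowest of the two numbers measured so far, and the one step that has been measured, a number 18.5 percentage points lower from compound 1 to compound 2 (beyond the scatter), shows that swapping the ring on the carbon with a double bond to nitrogen can move the read-out by a modest amount. Compound 3 `COc1ccc(/C=N/NC(=O)c2cccnc2Nc2cccc(C(F)(F)F)c2)c(OC)c1` changes that same ring again: 2,4-dimethoxyphenyl in place of 4-hydroxyphenyl on a carbon with a double bond to nitrogen. Among the compounds with values here, only the step from compound 1 to compound 2 bears on this change, and it was modest, so a step of similar size is expected here, with no clear direction that the two measured compounds can settle. The estimate for compound 3 is therefore 66%, within 50% to 82%, which would mean an expected step of a number 6.7 percentage points higher from compound 2 to compound 3 (within the scatter).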

Compound 3, a percentage reported as inhibition, in the whole organism at one dose (the size of the read-out at that dose, not a potency): 37.8%
Compound 3: the middle estimate sits 28.2 percentage points above what was measured; measured number outside the range, below it.
By their numbers in this assay, from the lowest: compound 3; then compound 2; then compound 1.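

In this assay, the ring on the carbon with a double bond to nitrogen again moves the read-out, with a number 21.5 percentage points lower from compound 2 to compound 3 (beyond the scatter), so the three compounds now cover a wide range, with a number 40 percentage points lower from compound 1 to compound 3 (beyond the scatter). The 2,4-dimethoxyphenyl group differs from 4-hydroxyphenyl in heavy atoms, hydrogen-bond donors and hydrogen-bond acceptors all at once, and this single step cannot separate those differences. No measurement at hand explains why the number falls. Going by these compounds, it remains open whether 4-methoxyphenyl, with one methoxy group in place of two, would give a number closer to that of compound 2 or that of compound 3. On these data alone, it is equally open how a ring carrying an amine or a carboxylic acid would compare with the core's three known rings.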